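A Small Methyl Step in a Level Solubility Series

The compounds below may be only part of what the source reports. "The series", "measured", "known", "first", "only" and "open" are said of these compounds alone.

In a physicochemical assay for solubility, read by HPLC, in phosphate buffer, with a stated time of 24 h, at pH 7.4, tested at 100 uM (on this read-out lower numbers stand for lower solubility and higher numbers for higher solubility), compound 1 `O=C(CCCCCNc1c(Nc2ccccc2)c(=O)c1=O)NO` gives 47000000 nM, compound 2 `C[C@@H](Nc1c(NCCCCCC(=O)NO)c(=O)c1=O)c1ccccc1` gives 80000000 nM and compound 3 `C[C@H](Nc1c(NCCCCCC(=O)NO)c(=O)c1=O)c1ccccc1` gives 73000000 nM. Compound 2 therefore stands level with the other two, not apart from them. Placing 1-phenylethyl where phenyl stood on a nitrogen gives a 1.7-fold higher number from compound 1 to compound 2 (0.23 log units; within the scatter), and the same exchange also gives a 1.6-fold higher number from compound 1 to compound 3 (0.19 log units; within the scatter). The remaining pair is set apart only by the fact that compounds 2 and 3 differ only in the configuration as drawn, and that comparison gives a 1.1-fold lower number from compound 2 to compound 3 (0.04 log units; within the scatter).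

Compound 4 `Cc1cccc([C@@H](C)Nc2c(NCCCCCC(=O)NO)c(=O)c2=O)c1` keeps everything in compound 2 except for one small change: methyl in place of hydrogen on an aromatic carbon. In words, this is methyl in place of hydrogen on an aromatic carbon, so phenyl becomes 3-methylphenyl. Within the data shown here, no measured pair tests this exact change, so the three steps above are the nearest guide. Even the exchange of whole groups in a 1.7-fold higher number from compound 1 to compound 2 (0.23 log units; within the scatter) stays within the normal spread of repeat measurements. On that basis, no step beyond the scatter is expected in this assay, and no firm direction can be assigned. The estimated change is a 1.3-fold lower number from compound 2 to compound 4 (0.12 log units; within the scatter), which is a small step of that kind. For compound 4 the expected value is 60000000 nM, with an estimated range from 33000000 nM to 95000000 nM.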

Compound 4, solubility: 89000000 nM
Estimate against measurement, compound 4: 1.5-fold (0.17 log units) below; measured number inside the range.
By their numbers in this assay, from the lowest: compounds 1, 3, 2 and 4 (each within the scatter of the next).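

In this assay, turning phenyl into 3-methylphenyl gives a 1.1-fold higher number from compound 2 to compound 4 (0.05 log units; within the scatter), so a single added carbon at this place leaves compound 4 level with compound 2. Among these compounds, the earlier compounds altered the group on the nitrogen or the configuration as drawn, but none of them carried a substituent on the aromatic ring itself; this pair is the first to show that a methyl on an aromatic carbon, meta to a large group, can be added without a step that stands out from the scatter of repeated measurements. Nothing on hand offers a reason for this level result.

The compounds shown carry only methyl at this place, so they leave open whether an amine or a carboxylic acid there would also stay level with compound 2, or would instead produce a step beyond the scatter. They also leave open whether a methyl at another carbon of the same ring, or the same methyl on the opposite configuration found in compound 3, would read the same way.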